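Swapping an Aromatic Ring for an Open Chain

The source may report more compounds than this note shows. Statements on the series, on what has been measured and on what is new or still open speak of the compounds shown alone.

Measured so far:
compound 1, `c1ccc(-c2cnco2)c(NCC2=NCCN2)c1`: 17.4 nM
compound 2, `c1coc(-c2ccccc2NCC2=NCCN2)c1`: 0.468 nM
compound 3, `c1ccc(-c2cnoc2)c(NCC2=NCCN2)c1`: 45.7 nM

In a functional assay for activation of Alpha-1A adrenergic receptor (Homo sapiens), read by calcium flux (a lower number here means that less compound is needed, a higher number that more compound is needed for the effect), compound 3 gives the highest number of the three. The step of a 2.6-fold higher number from compound 1 to compound 3 (0.42 log units; beyond the scatter) is modest, whereas a 98-fold higher number from compound 2 to compound 3 (1.99 log units; beyond the scatter) is large, so small exchanges at this one position have moved the number both a little and a lot. Compound 4 `CC/C(=N/OC)c1ccccc1NCC1=NCCN1` differs from compound 3 at the same position: a group of 6 heavy atoms (4 carbon, 1 nitrogen, 1 oxygen; no ring) in place of a group of 5 heavy atoms (3 carbon, 1 nitrogen, 1 oxygen; one five-membered aromatic ring with 2 hetero atoms), on an aromatic carbon. Going by the values given here, none of the measured steps replaces a ring with an open chain, so none bears directly on this change; they only show that the position is sensitive. The direction is therefore uncertain. The estimate for compound 4 in this assay is 15 nM, within a range from 1.5 nM to 150 nM. This amounts to an expected step of a 3.0-fold lower number from compound 3 to compound 4 (0.48 log units; beyond the scatter).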

Compound 4, half-maximal effective concentration: 87.1 nM
The estimate for compound 4 lay 5.8-fold (0.76 log units) below the measured number, and the stated range covers the measured number.
By their numbers in this assay, from the lowest: compound 2; then compound 1; then compounds 3 and 4 (each within the scatter of the next).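

In this assay, an open chain can take the place of a ring on this aromatic carbon: a 1.9-fold higher number from compound 3 to compound 4 (0.28 log units; within the scatter), so this exchange leaves the number where the 1,2-oxazol-4-yl compound had it. The same chain fares worse against the other two rings, with a 5.0-fold higher number from compound 1 to compound 4 (0.70 log units; beyond the scatter) and, far larger, a 190-fold higher number from compound 2 to compound 4 (2.27 log units; beyond the scatter). Nothing available explains these differences. As far as these compounds go, whether a different open chain, such as an ester or an amide, could approach compound 2 remains open. So does whether a phenyl ring at this position would match the furan-2-yl group of compound 2.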